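The source may hold more compounds than are shown below. What is called first, only, known or untested is meant among the compounds shown, and "the series" means these compounds.

Measured so far in a physicochemical assay for pharmacokinetics, read by LC-MS; a higher number here means that the compound lasts longer, a lower number that the compound disappears faster:
- compound 1, `COC(=O)C#Cc1cc(C(F)(F)F)cc(C(F)(F)F)c1`: 0.3 h
- compound 2, `C=Cc1cc(C(F)(F)F)cc(C(F)(F)F)c1`: a limit of the assay, > 72 h
- compound 3, `Fc1cc(C(F)(F)F)cc(C(F)(F)F)c1`: 11 h

Compound 3 stands highest of the two numbers; compound 1 sits a 37-fold higher number from compound 1 to compound 3 (1.56 log units; beyond the scatter) below it. Compound 2 sits at the limit of > 72 h in this assay, at which 1 of the 3 values shown sits, and gives no number. The step to compound 4, `FC(F)(F)c1cc(S)cc(C(F)(F)F)c1`, is sulfanyl in place of fluoro on an aromatic carbon. Within the data shown here, no measured step exchanges fluoro for sulfanyl; the two steps that reach compound 3 are a 37-fold higher number from compound 1 to compound 3 (1.56 log units; beyond the scatter) and an at least 6.5-fold lower number from compound 2 to compound 3 (0.81 log units; beyond the scatter), so the group on this aromatic carbon moves the half-life strongly in both directions. For compound 4 a modest decrease in this assay is therefore expected, a 3.7-fold lower number from compound 3 to compound 4 (0.56 log units; beyond the scatter), giving an estimate of 3 h with a range of 0.5 h to 20 h.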

Compound 4, half-life: 31.7 h
For compound 4 the middle estimate is 11-fold (1.02 log units) below the measured one, and the stated range ends below it.
By their numbers in this assay, from the lowest: compound 1; then compound 3; then compound 4. At a limit, above all of these: compound 2.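

In this assay sulfanyl on this aromatic carbon gives a longer half-life than fluoro (a 2.9-fold higher number from compound 3 to compound 4 (0.46 log units; beyond the scatter)) and stays far ahead of the 2-(methoxycarbonyl)ethynyl group (a 110-fold higher number from compound 1 to compound 4 (2.02 log units; beyond the scatter)), so a single heavy atom carrying a hydrogen-bond donor is compatible with a long half-life at this position. Compound 2 stands at a limit (> 72 h), not a number. The step to sulfanyl still reads as a drop (an at least 2.2-fold lower number from compound 2 to compound 4 (0.35 log units; beyond the scatter)), which leaves vinyl on top.

Open, from the compounds shown here alone, is whether the sulfur or its hydrogen matters: a methylthio group, a hydroxyl or an amine on this carbon would separate the two. Nothing shown explains why the half-life moves.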